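Methyl in Place of Chloro: Awaiting Compound 4

The source may report more compounds than this note shows. Statements on the series, on what has been measured and on what is new or still open speak of the compounds shown alone.

The measured compounds are:

Compound 1, `CC(C)Nc1nc(NCc2ccco2)c2ccc(Cl)cc2n1`, which in a physicochemical assay for permeability, using PAMPA, at pH 7.4 (a higher number here means that the compound crosses the layer faster, a lower number that the compound crosses the layer more slowly), gives 1380 10^-6 cm/s.
Compound 2, `CC(C)Nc1nc(NCc2ccco2)c2cc(Cl)ccc2n1`, which in this assay gives 1630 10^-6 cm/s.
Compound 3, `Cc1ccc2c(NCc3ccco3)nc(NC(C)C)nc2c1`, which in this assay gives 798 10^-6 cm/s.

Compound 1 and compound 2 are built from the same atoms joined differently; the difference between the two cores is not broken down here. Their two values lie within the scatter of each other, so nothing separates them in this assay.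

Compound 3 differs from compound 1 by methyl in place of chloro on an aromatic carbon. This change produced a 1.7-fold lower number from compound 1 to compound 3 (0.24 log units; within the scatter), a step that stays within the usual scatter.

Compound 4, `Cc1ccc2nc(NC(C)C)nc(NCc3ccco3)c2c1`, has not yet been measured. Within the data shown here, it differs from compound 2 by methyl in place of chloro on an aromatic carbon, the same change at the same kind of place as the one made from compound 1 to compound 3, here on the core of compound 2.

The expectation for compound 4 rests on a single earlier step: because a 1.7-fold lower number from compound 1 to compound 3 (0.24 log units; within the scatter) was small, the same change on the core of compound 2 is expected to give a step of similar size, a 1.7-fold lower number from compound 2 to compound 4 (0.23 log units; within the scatter). On that basis compound 4 is expected to give 960 10^-6 cm/s in this assay, with a likely range from 600 10^-6 cm/s to 1500 10^-6 cm/s. Among the measured compounds shown here, with only one precedent for the change, that range is kept wide.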

Compound 4, apparent permeability: 789 10^-6 cm/s
Compound 4: the middle estimate sits 1.2-fold (0.09 log units) above what was measured; measured number inside the range.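

In this assay, methyl in place of chloro gave a 2.1-fold lower number from compound 2 to compound 4 (0.32 log units; beyond the scatter), and the earlier pair on the other core gave a 1.7-fold lower number from compound 1 to compound 3 (0.24 log units; within the scatter), so the change went the same way on both cores, with the first of these steps lying beyond the scatter and the second within it. This supports carrying the change from the core of compound 1 to the core of compound 2 as far as direction goes, but it rests on only these two pairs and does not show that the change would act the same way on any other core in the series, or that the step beyond the scatter marks a real difference between the two cores. Nothing given here bears on why the number falls with this change on either core.

The compounds shown leave open whether the same step would appear on a third core, since chloro and methyl have been compared on just two. They also leave open how other groups on that aromatic carbon, such as methoxy, an amine or a carboxylic acid, would compare with chloro and methyl in this assay.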